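From methyl to trifluoromethyl: compound 3 to compound 4

This account rests on a few compounds, and the source may have more. Where it says the series, first, only, none or still open, it means among the compounds named here.

Compound 1 `Fc1ccccc1NC(=S)N/N=C/c1ccc2ccccc2n1`: > 100000 nM, a limit and not a number
Compound 2 `S=C(NCc1ccccc1)N/N=C/c1ccc2ccccc2n1`: 75700 nM
Compound 3 `Cc1ccc(NC(=S)N/N=C/c2ccc3ccccc3n2)cc1`: 85500 nM

In a functional assay on HT-29 cells (Homo sapiens) for antiproliferative activity, read by sulforhodamine B assay, with a stated time of 72 h (on this read-out higher numbers stand for weaker inhibition and lower numbers for stronger inhibition), compound 3 stands level with its nearest neighbour, with a 1.1-fold higher number from compound 2 to compound 3 (0.05 log units; within the scatter). Compound 4 `FC(F)(F)c1ccc(NC(=S)N/N=C/c2ccc3ccccc3n2)cc1` carries trifluoromethyl in place of methyl on an aromatic carbon, para to a large group: trifluoromethyl in place of methyl on an aromatic carbon. Going by the values given here, no measured step changes that methyl itself. The closest evidence is an at least 1.1-fold lower number from compound 1 to compound 3 (0.06 log units; that floor lies within the scatter), and it rests on a limit. With a 1.1-fold higher number from compound 2 to compound 3 (0.05 log units; within the scatter) also small, no step beyond the scatter is expected. The expected change is a 1.3-fold lower number from compound 3 to compound 4 (0.12 log units; within the scatter). For compound 4 the estimate is 65000 nM, with an expected range of 22000 nM to 100000 nM.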

Compound 4, half-maximal inhibitory concentration: 63900 nM
Estimate against measurement, compound 4: 1.0-fold (0.01 log units) above; low and high end bracket the measured number.
By their numbers in this assay, from the lowest: compounds 4, 2 and 3 (each within the scatter of the next). At a limit, above all of these: compound 1.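

In this assay, going by these compounds alone, the substituent on this aromatic carbon, para to a large group, is changed directly for the first time, and trifluoromethyl in place of methyl gives a 1.3-fold lower number from compound 3 to compound 4 (0.13 log units; within the scatter). Within the data shown here, four heavy atoms in place of one therefore leave compound 3 and compound 4 level, whereas the earlier steps changed only the group on the nitrogen. Comparisons in this series are also bounded at the upper end of the read-out: the limit of > 100000 nM in this assay, at which 1 of the 4 values shown sits.

On these data alone, whether an amine, a carboxylic acid or a longer chain at this position would move the number beyond the scatter remains open.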